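The source may report more compounds than this note shows. Statements on the series, on what has been measured and on what is new or still open speak of the compounds shown alone.

Measured compounds:

- compound 1, `Cc1ccnc2nc(-c3cccc4ccccc34)cc(O)c12`: < 10 nM
- compound 2, `Cc1cc(C)c2c(O)cc(-c3cccc4ccccc34)nc2n1`: 234 nM
- compound 3, `Cc1ccc2c(O)cc(-c3ccc4ccccc4c3)nc2n1`: 1950 nM

All three were tested in a functional assay on MDA-N cells (Homo sapiens) for antiproliferative activity; on this read-out lower numbers stand for stronger inhibition of growth and higher numbers for weaker inhibition of growth. For compound 1 the read-out of < 10 nM is a limit of the assay, not a number; the value sits at the limit of < 10 nM in this assay, at which 1 of the 3 values shown sits. Compound 2 gives 234 nM, and compound 3 gives 1950 nM, the higher of the two numbers actually measured.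

Compound 1 and compound 2 differ in one place: methyl in place of hydrogen on an aromatic carbon. This change brought an at least 23-fold higher number from compound 1 to compound 2 (1.36 log units; beyond the scatter). How the core of compound 3 differs from the core of compound 1 is not broken down here; the two have the same atoms, joined differently.

Compound 4, `Cc1cc(C)c2c(O)cc(-c3ccc4ccccc4c3)nc2n1`, has not yet been measured. It differs from compound 3 in one place: methyl in place of hydrogen on an aromatic carbon. Within the data shown here, this is the same kind of change as the one from compound 1 to compound 2, but not the same: there the methyl sat next to the ring nitrogen and para to a fused ring, whereas here it sits ortho to a fused ring and opposite the ring nitrogen.

Among the measured compounds shown here, because the only measured methyl step is an at least 23-fold higher number from compound 1 to compound 2 (1.36 log units; beyond the scatter), the expectation for compound 4 in this assay is a weakening, though a smaller one since the place differs, giving an estimated 2.3-fold higher number from compound 3 to compound 4 (0.36 log units; beyond the scatter). Compound 4 is therefore expected to give about 4500 nM, most likely between 1200 nM and 16000 nM.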

Compound 4, concentration for 50% growth inhibition: 3240 nM
Compound 4: the middle estimate sits 1.4-fold (0.14 log units) above what was measured; the measured number falls inside the stated range.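

In this assay, methyl in place of hydrogen on an aromatic carbon gives a 1.7-fold higher number from compound 3 to compound 4 (0.22 log units; within the scatter), so on this core the effect of the change cannot be told apart from the ordinary spread of repeated measurements. Set beside the earlier step, the same change clearly does not carry over from one core to the other with the same size: the same change on two cores in this assay, an at least 23-fold higher number (1.36 log units; beyond the scatter) from compound 1 to compound 2 and a 1.7-fold higher number (0.22 log units; within the scatter) from compound 3 to compound 4, at least 14-fold (1.14 log units) apart, beyond the scatter of two such steps Compound 1 gives < 10 nM, which is a limit and not a number, and a comparison of just two cores tells neither the full size of this gap nor what lies behind it, so no general rule for the methyl change in this series follows.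

The compounds shown leave open whether a group other than methyl, such as an ethyl chain, an amine or a carboxylic acid, placed opposite the ring nitrogen on the core of compound 3, would move the number by more than the scatter. They also leave open how the methyl change would behave on further cores, which would show whether the large step or the small one is the more typical.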